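The source may hold more compounds than are shown below. What is called first, only, known or untested is meant among the compounds shown, and "the series" means these compounds.

Working notes on the series.

Of the compounds shown here, three sharing one core have been measured in a physicochemical assay for lipophilicity, using the shake flask method, in phosphate buffer, measured as octanol-water partition, with a stated time of 30 min, at pH 7.4; on this read-out higher numbers stand for higher lipophilicity and lower numbers for lower lipophilicity. Compound 1 `CN(c1ccn(C)n1)c1cnc(NCc2c(F)ccc3c2CCO3)c2cn[nH]c(=O)c12` gives 2.4. Compound 2 `CC1(C)CC(=O)N(c2cnc(NCc3c(F)ccc4c3CCO4)n3cnnc23)C1` gives 2, and compound 3 `O=C1CC2(CC2)CN1c1cnc(NCc2c(F)ccc3c2CCO3)n2cnnc12` gives 1.9. Compound 3 stands lowest of the three: the gap to compound 2 is within the scatter, while compound 1 sits clearly higher. Going by the values given here, the one single-point step measured so far, a number 0.10 log units lower from compound 2 to compound 3 (within the scatter), exchanged two ring-bearing groups of equal atom count at the same aromatic carbon and left the read-out unchanged.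

Compound 4 `COCCC(=O)Nc1cnc(NCc2c(F)ccc3c2CCO3)n2cnnc12` is not yet measured. It differs from compound 3 in the same position: a group of 7 heavy atoms (4 carbon, 1 nitrogen, 2 oxygen; no ring) in place of a group of 8 heavy atoms (6 carbon, 1 nitrogen, 1 oxygen; one three-membered non-aromatic ring of carbon only, one five-membered non-aromatic ring with 1 hetero atom), on an aromatic carbon. This step bears only loosely on the earlier one, since here both rings are lost and a donor and an acceptor enter, where the step from compound 2 to compound 3 kept atom count and donor and acceptor count fixed. Among the compounds with values here, no measured step covers such an exchange. On the basis of the step from compound 2 to compound 3 alone no shift beyond the scatter would be expected; the added donor and acceptor and the loss of both rings are taken to push the estimate down, so a step of a number 0.40 log units lower from compound 3 to compound 4 (beyond the scatter) is expected. Compound 4 is therefore estimated at 1.5, within 1 to 2.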

Compound 4, distribution coefficient: 1.4
Beside the measured number, compound 4's estimate is 0.10 log units above it, within the range that was stated.
By their numbers in this assay, from the lowest: compound 4; then compounds 3 and 2 (each within the scatter of the next); then compound 1.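

In this assay this position proves responsive: the exchange between two ring-bearing groups stayed within the scatter, whereas the open-chain ((2-methoxyethyl)carbonyl)amino gives a number 0.50 log units lower from compound 3 to compound 4 (beyond the scatter) and, set against 4,4-dimethyl-2-oxopyrrolidin-1-yl, a number 0.60 log units lower from compound 2 to compound 4 (beyond the scatter) in the same direction. The shift therefore does not depend on which of the two ring-bearing groups is taken as the starting point. The change removes the rings and alters the hydrogen-bond donor and acceptor counts together, so these single steps cannot separate the contributions, and no measurement at hand accounts for the shift.

Going by these compounds, whether a plain amine, a longer chain without the ether oxygen, or a carboxylic acid at this position would follow compound 4 remains open. Also open, on these data alone, is whether the same exchange would carry over to the core of compound 1.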